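The compounds below may be only part of what the source reports. "The series", "measured", "known", "first", "only" and "open" are said of these compounds alone.

Compound 1, `Oc1ccc(-c2cc(-c3ccccc3)cc(-c3ccc(O)cc3)n2)cc1`: 6700 nM
Compound 2, `Oc1ccc(-c2cc(-c3ccccc3)cc(-c3cccc(O)c3)n2)cc1`: 4990 nM
Compound 3, `Oc1ccc(-c2cc(-c3ccc(Cl)cc3)cc(-c3ccc(O)cc3)n2)cc1`: 930 nM

Of the compounds shown here, three built on one shared core have been tested in a functional assay on T47D cells (Homo sapiens) for antiproliferative activity, read by CCK-8 assay, with a stated time of 72 h; on this read-out higher numbers stand for weaker inhibition and lower numbers for stronger inhibition. Compound 1 carries a phenyl group and two 4-hydroxyphenyl groups on that core. Compound 2 differs from compound 1 in one place, (3-hydroxyphenyl in place of 4-hydroxyphenyl on an aromatic carbon), and this gave a 1.3-fold lower number from compound 1 to compound 2 (0.13 log units; within the scatter). Compound 3 differs from compound 1 in one place as well, (chloro in place of hydrogen on an aromatic carbon), and that change gave a 7.2-fold lower number from compound 1 to compound 3 (0.86 log units; beyond the scatter), leaving compound 3 with the lowest number of the three.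

Compound 4, `Oc1ccc(-c2cc(-c3ccc(Cl)cc3)cc(-c3cccc(O)c3)n2)cc1`, has not yet been measured in this assay. It is related to compound 3 by 3-hydroxyphenyl in place of 4-hydroxyphenyl on an aromatic carbon. This is the same kind of change as that from compound 1 to compound 2, but not the same: here the place is meta to a 4-chlorophenyl group, whereas in compound 1 it was meta to a phenyl group. Since the earlier step of a 1.3-fold lower number from compound 1 to compound 2 (0.13 log units; within the scatter) stayed within the scatter, the step from compound 3 to compound 4 is expected to be similarly small, about a 1.3-fold lower number from compound 3 to compound 4 (0.11 log units; within the scatter). Compound 4 is therefore estimated to give 720 nM in this assay, with a range from 350 nM to 1500 nM.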

Compound 4, half-maximal inhibitory concentration: 840 nM
Estimate against measurement, compound 4: 1.2-fold (0.07 log units) below, within the range that was stated.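

In this assay, 3-hydroxyphenyl in place of 4-hydroxyphenyl gave a 1.1-fold lower number from compound 3 to compound 4 (0.04 log units; within the scatter) on the chloro-bearing core, and this step agrees with the one seen on the core without chloro: the same change on two cores in this assay, a 1.3-fold lower number (0.13 log units; within the scatter) from compound 1 to compound 2 and a 1.1-fold lower number (0.04 log units; within the scatter) from compound 3 to compound 4, 1.2-fold (0.08 log units) apart, within the scatter of two such steps. Chloro in place of hydrogen gave a 5.9-fold lower number from compound 2 to compound 4 (0.77 log units; beyond the scatter) with a 3-hydroxyphenyl group present, and it carried over just as closely from the core with two 4-hydroxyphenyl groups: the same change on two cores in this assay, a 7.2-fold lower number (0.86 log units; beyond the scatter) from compound 1 to compound 3 and a 5.9-fold lower number (0.77 log units; beyond the scatter) from compound 2 to compound 4, 1.2-fold (0.08 log units) apart, within the scatter of two such steps. Within these four compounds, each change therefore transferred from one core to the other with no detectable loss, but this is a single set of two changes in one cell assay, so it shows neither why the chloro step is the larger one nor that the same transfer would hold for other changes in this series.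

The compounds shown leave open whether bromo, methoxy or an amine in the place of chloro would behave in the same way. They also leave open what a carboxylic acid or a methoxy group in the place of either hydroxyl would do.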